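Thiophene replaces nitrophenyl at the imine carbon of compound 2

This account rests on a few compounds, and the source may have more. Where it says the series, first, only, none or still open, it means among the compounds named here.

Three pyrazoline thioureas have been measured so far. Compound 1 `CSc1ccc(C2=NN(C(=S)Nc3ccccc3)C(c3ccc4c(c3)OCCO4)C2)cc1` gives 197000 nM in a functional assay on WM 266-4 cells (Homo sapiens) for antiproliferative activity, read by MTT assay, with a stated time of 48 h; a higher number here means a weaker inhibitor of growth, a lower number a stronger inhibitor of growth. Compound 2 `O=[N+]([O-])c1ccc(C2=NN(C(=S)Nc3ccccc3)C(c3ccc4c(c3)OCCO4)C2)cc1` gives 105000 nM in this assay, the second highest of the three numbers. Compound 3 `S=C(Nc1ccccc1)N1N=C(c2ccc(OCc3ccccc3)cc2)CC1c1ccc2c(c1)OCCO2` gives 420 nM in this assay. The change a 1.9-fold lower number from compound 1 to compound 2 (0.27 log units; within the scatter) lies within the scatter, whereas a 470-fold lower number from compound 1 to compound 3 (2.67 log units; beyond the scatter) and a 250-fold lower number from compound 2 to compound 3 (2.40 log units; beyond the scatter) are large.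

Compound 4 `S=C(Nc1ccccc1)N1N=C(c2cccs2)CC1c1ccc2c(c1)OCCO2` has not yet been measured. It differs from compound 2 by thiophen-2-yl in place of 4-nitrophenyl on a carbon with a double bond to nitrogen. Within the data shown here, no measured step carries a thiophen-2-yl group at that carbon, so the data offer no direct guide. Among the measured compounds shown here, the one large change seen, from compound 2 to compound 3, came with a benzyloxy group, which compound 4 does not carry; the move from methylsulfanyl to nitro between compound 1 and compound 2 changed little. Compound 4 is therefore expected to land near compounds 1 and 2, with at most a modest step of a 1.8-fold lower number from compound 2 to compound 4 (0.24 log units; within the scatter). The estimate for compound 4 in this assay is 60000 nM, with a range from 10000 nM to 200000 nM.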

Compound 4, concentration for 50% growth inhibition: 154000 nM
Compound 4: middle estimate off by 2.6-fold (0.41 log units), on the low side; low and high end bracket the measured number.
By their numbers in this assay, from the lowest: compound 3; then compounds 2, 4 and 1 (each within the scatter of the next).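

Put at the carbon with a double bond to nitrogen in this assay, thiophen-2-yl gives no step beyond the scatter from either phenyl group: a 1.5-fold higher number from compound 2 to compound 4 (0.17 log units; within the scatter) and a 1.3-fold lower number from compound 1 to compound 4 (0.11 log units; within the scatter). A five-membered aromatic ring with one sulfur therefore reads the same here as 4-nitrophenyl and 4-(methylsulfanyl)phenyl, and of the compounds at this position only compound 3 , at 420 nM, goes against this flat picture. Nothing available explains why these groups read alike.

The compounds shown leave open whether the large drop needs the whole benzyloxy group or would also appear with a methoxy group, a longer chain such as butoxy, or a benzylamino group on the phenyl ring. They also leave open whether a benzyloxy group carried on the thiophene would act as it does on the phenyl ring.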